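The source may report more compounds than this note shows. Statements on the series, on what has been measured and on what is new or still open speak of the compounds shown alone.

Of the compounds shown here, two that share one core have been measured so far. Compound 1 `Cc1ccc(-c2sc(N)c(C(=O)c3ccc(Cl)cc3)c2CC(C)(C)C)cc1` gives 1% in an assay on CHO cells for displacement of a labelled ligand from adenosine receptor A1 (Homo sapiens), read by scintillation counting, tested at 10 uM; a lower number here means less inhibition, a higher number more inhibition at the concentration tested (going by the name of the read-out). Among the compounds with values here, compound 2 `COc1ccc(-c2sc(N)c(C(=O)c3ccc(Cl)cc3)c2CC(C)(C)C)cc1` gives 1% in this assay, and the step of no change at the digits printed from compound 1 to compound 2 (within the scatter) leaves compound 2 level with compound 1 on the numbers so far. Compound 3 `CC(C)(C)Cc1c(-c2ccco2)sc(N)c1C(=O)c1ccc(Cl)cc1` is the next one; against compound 2 it differs by furan-2-yl in place of 4-methoxyphenyl on an aromatic carbon. Within the data shown here, only the step from compound 1 to compound 2 bears on this change: it swapped one group on an aromatic carbon and did not move the read-out, but it kept a six-membered ring, whereas here a five-membered ring with one hetero atom enters, so that step covers the new case only loosely. With both measured compounds showing almost no inhibition, the expected step of a number 2 percentage points higher from compound 2 to compound 3 (within the scatter) is none beyond the scatter. Compound 3 is therefore estimated at 3%, between -8% and 16%.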

Compound 3, a percentage reported as inhibition, at one concentration (the size of the read-out at that concentration, not a potency): 1%
The estimate for compound 3 lay 2 percentage points above the measured number; low and high end bracket the measured number.
By their numbers in this assay, from the lowest: compounds 1, 2 and 3 (each within the scatter of the next).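

In this assay the steps of no change at the digits printed from compound 2 to compound 3 (within the scatter) and no change at the digits printed from compound 1 to compound 3 (within the scatter) extend the flat read-out at this place, next to the ring sulfur, from six-membered aromatic rings of carbon only to a five-membered aromatic ring with one hetero atom. Furan-2-yl also has fewer heavy atoms than 4-methoxyphenyl, so neither the ring size nor the size of the group separates these compounds, although with so little inhibition throughout, this does not show that the position is indifferent. Nothing given here explains this flat result.

The compounds shown leave open whether a group of another kind at this place, such as an amine or a carboxylic acid, would raise the inhibition. They also leave open whether a longer chain in place of the neopentyl group would do so.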